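Fluoro in place of hydrogen on compound 2

The source may report more compounds than this note shows. Statements on the series, on what has been measured and on what is new or still open speak of the compounds shown alone.

Three measured entries share one core: compound 1 (`O=C1c2c(ccc(O)c2O)CN1Cc1ccc(F)cc1`), compound 2 (`O=C1c2c(ccc(O)c2O)CN1Cc1cccc(F)c1`) and compound 3 (`O=C1c2c(ccc(O)c2O)CN1Cc1cccc(Br)c1`). In an ADME assay on HOS cells (Homo sapiens) for cytotoxicity (on this read-out higher numbers stand for weaker inhibition and lower numbers for stronger inhibition), compound 1 was "not determined" (no result reported), so it offers no comparison. Compound 2 gives 8600 nM and compound 3 gives 7240 nM. Among the measured compounds shown here, these are the only two numbers available, and they lie within the scatter of each other, so compound 2 stands level with its sole neighbour.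

Compound 4 (`O=C1c2c(ccc(O)c2O)CN1Cc1ccc(F)c(F)c1`) has not yet been measured. Its difference from compound 2 is fluoro in place of hydrogen on an aromatic carbon. For the measured compounds named here, only one measured step bears on this change, bromo in place of fluoro on an aromatic carbon, and it shows a 1.2-fold lower number from compound 2 to compound 3 (0.07 log units; within the scatter). That step is of another kind and is only a loose guide, but it offers no reason to predict a large move in either direction. No shift beyond the scatter is therefore expected in this assay. The expected step is a 1.1-fold lower number from compound 2 to compound 4 (0.03 log units; within the scatter). The estimated value for compound 4 is 8000 nM, within an expected range of 3500 nM to 18000 nM.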

Compound 4, half-maximal inhibitory concentration: 9010 nM
For compound 4 the middle estimate is 1.1-fold (0.05 log units) below the measured one; low and high end bracket the measured number.
By their numbers in this assay, from the lowest: compounds 3, 2 and 4 (each within the scatter of the next).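

In this assay the added fluoro group gives a 1.0-fold higher number from compound 2 to compound 4 (0.02 log units; within the scatter), so filling this aromatic carbon, ortho to a fluoro group and para to a large group, leaves the number level with that of compound 2. The earlier step only exchanged one halogen for another, whereas this one puts a halogen where hydrogen stood, and that addition also stays within the scatter. Nothing available offers an explanation for this result.

On these data alone, whether an amine or a methoxy group at this same carbon would also leave the number level remains open. Steps involving compound 1 cannot be read, so what the fluoro group para to a large group contributes on its own also stays unknown.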